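This account rests on a few compounds, and the source may have more. Where it says the series, first, only, none or still open, it means among the compounds named here.

Compound 2 `CC(C)C[C@H](N)c1cc(C(F)(F)F)ccc1N1CCN(C(=O)COc2ccc([N+](=O)[O-])cc2)CC1` shares its core with compound 1 `CC(C)C[C@H](N)c1cc(C(F)(F)F)ccc1N1CCN(C(=O)C(C)Cc2ccc(Cl)c(Cl)c2)CC1` and differs from it only in the group carried on the carbonyl side chain. Among the compounds with values here, in an assay on HEK293 cells for displacement of a labelled ligand from Melanocortin receptor 4 (Homo sapiens) (on this read-out lower numbers stand for stronger inhibition and higher numbers for weaker inhibition), compound 1 gives 120 nM; 1600 nM (2 entries), while compound 2 gives 3100 nM, the only number recorded for it, beside one further entry that holds no single number. Compound 3 `CC(C)C[C@H](N)c1cc(C(F)(F)F)ccc1N1CCN(C(=O)CCC(=O)N(C)C)CC1` differs from compound 2 by (dimethylcarbamoyl)methyl in place of 4-nitrophenoxy on a saturated chain carbon bound to a carbonyl carbon. Within the data shown here, no measured pair isolates this change, so the step of a 1.9-fold higher number from compound 2 to compound 3 (0.29 log units; within the scatter) is expected to be a modest loss, barely beyond the scatter. Compound 3 is therefore estimated at 6000 nM, between 1500 nM and 25000 nM.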

Compound 3, inhibition constant: > 10000 nM
Compound 3 gave a limit, no number; the forecaster's own chance of this, stated with the estimate: 30%; middle value at least 1.6-fold (0.22 log units) away from the limit.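

In this assay compound 3 gives > 10000 nM, which is a limit of the assay and not a number. Even so, the change reads as an at least 3.2-fold higher number from compound 2 to compound 3 (0.50 log units; beyond the scatter), the first step at this position that isolates a single change. Replacing 4-nitrophenoxy with (dimethylcarbamoyl)methyl on this saturated chain carbon therefore costs binding by more than the scatter. As far as these compounds go, the true size of the step remains open. Also open, from the compounds shown here alone, is whether it follows the departing aromatic ring or the entering dimethylcarbamoyl group; an unsubstituted phenoxy group or a carboxylic acid on the same chain would separate the two.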